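This account rests on a few compounds, and the source may have more. Where it says the series, first, only, none or still open, it means among the compounds named here.

Measured in a functional assay on the whole organism (strain Sprague-Dawley) for inhibition, with Rattus norvegicus as the target, with a stated time of 10 min; on this read-out lower numbers stand for an effect already at smaller amounts and higher numbers for an effect only at larger amounts of compound:
Compound 1 `O=C(O)c1cnc(-c2ccccc2)[nH]c1=O`: 50 mg/kg
Compound 2 `O=C(O)c1cnc(-c2ccccc2O)[nH]c1=O`: > 5 mg/kg (a limit)
Compound 3 `CCCOc1ccccc1-c1ncc(C(=O)O)c(=O)[nH]1`: 0.9 mg/kg

Compound 3 carries the lowest of the two exact numbers, with the value of compound 2 being only a limit. Compound 4 `CCCCCOc1ccccc1-c1ncc(C(=O)O)c(=O)[nH]1` lengthens the chain on the oxygen, propyl to pentyl: ethyl in place of hydrogen on a saturated chain carbon, three bonds along the chain from an oxygen on an aromatic ring. Going by the values given here, two measured steps bear on this change: a 56-fold lower number from compound 1 to compound 3 (1.74 log units; beyond the scatter), and an at least 5.5-fold lower number from compound 2 to compound 3 (0.74 log units; beyond the scatter). Both install the propyl chain, and neither varies its length, so their size does not carry over to this extension. No step beyond the scatter is expected in this assay, the expected step being a 1.1-fold lower number from compound 3 to compound 4 (0.05 log units; within the scatter). Compound 4 is estimated at 0.8 mg/kg, with an expected range of 0.2 mg/kg to 3.5 mg/kg.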

Compound 4, dose for 50% inhibition: 3 mg/kg
Compound 4: middle estimate off by 3.8-fold (0.57 log units), on the low side; the measured number falls inside the stated range.
By their numbers in this assay, from the lowest: compound 3; then compound 4; then compound 1.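

In this assay, the length of the chain on the oxygen now counts: propyl to pentyl gives a 3.3-fold higher number from compound 3 to compound 4 (0.52 log units; beyond the scatter). Measured against the core without any chain, there is still a 17-fold lower number from compound 1 to compound 4 (1.22 log units; beyond the scatter), so much of the gain over compound 1 survives the longer chain. Pentyl in place of hydrogen on the oxygen of compound 2 gives an at least 1.6-fold lower number from compound 2 to compound 4 (0.22 log units; that floor lies within the scatter), a floor resting on the limit of compound 2: the limit of > 5 mg/kg in this assay, at which 1 of the 4 values shown sits.

From the compounds shown here alone, two chain lengths cannot place an optimum, so ethyl, butyl and hexyl chains remain open. Going by these compounds, an amine or a carboxylic acid at the chain end is equally open.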